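Branching a Hydroxyalkoxy Chain on a Thiazole Amide

The source may hold more compounds than are shown below. What is called first, only, known or untested is meant among the compounds shown, and "the series" means these compounds.

Measured compounds:
- compound 1, `COc1ccc(C(=O)Nc2ncc(Cc3cccc(F)c3)s2)cc1OCCO`, 2 nM in an assay on microsomes for inhibition of acyl-CoA desaturase 1 (Mus musculus), with a stated time of 60 min; a lower number here means a stronger inhibitor, a higher number a weaker inhibitor
- compound 2, `COc1ccc(C(=O)Nc2ncc(Cc3cccc(C(F)(F)F)c3)s2)cc1OCCCO`, "not determined" (no result reported) in this assay

Going by the values given here, compound 1 is the only member of this small set with a number attached to it: in this assay compound 1 gives 2 nM. Compound 2 stands without a result in this assay, so nothing can be said of how it compares with compound 1 on the numbers shown; the two differ in more than one place, and no single change between them can be followed.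

Compound 3, `COc1ccc(C(=O)Nc2ncc(Cc3cccc(C(F)(F)F)c3)s2)cc1OCC(C)(C)O`, is the next compound to be measured in this assay. It derives from compound 2 by a single change: 1-hydroxy-1-methylethyl in place of 2-hydroxyethyl on a saturated chain carbon bound to an oxygen on an aromatic ring. Among the compounds with values here, no measured pair in this set isolates that change, so the size of the step cannot be read from the data. Within the data shown here, with compound 2 unmeasured, the only anchor is compound 1 at 2 nM in this assay, and compound 3 shares the core of compound 1 while carrying a trifluoromethyl group and a branched, hydroxylated side chain. On that basis compound 3 is expected to fall around 5 nM in this assay, within a range of 1 nM to 30 nM.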

Compound 3, half-maximal inhibitory concentration: > 9990 nM
Compound 3: a limit, no number; the forecaster's own chance of this, stated with the estimate: 5%; middle value at least 1900-fold (3.30 log units) away from the limit.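

No step can be read between compound 2 and compound 3, as compound 2 has no result. Compound 3 gives a limit and not a number: the limit of > 9990 nM in this assay, at which 1 of the 3 values shown sits. The compounds shown leave open whether the change from 3-hydroxypropoxy to 2-hydroxy-2-methylpropoxy, or another difference from compound 1, goes with this result.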